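The source may hold more compounds than are shown below. What is called first, only, known or untested is meant among the compounds shown, and "the series" means these compounds.

Measured so far:
Compound 1, `CN(C)CCn1cnnc1-c1cc(Oc2ccc(NC(=O)N/N=C/c3ccc(Cl)cc3Cl)cc2F)ccn1`: 4760 nM
Compound 2, `CN(C)CCn1cnnc1-c1cc(Oc2ccc(NC(=O)N/N=C/c3c(Cl)cccc3Cl)cc2F)ccn1`: 3320 nM

In an ADME assay on WI-38 cells (Homo sapiens) for cytotoxicity, read by MTT assay, with a stated time of 72 h (a lower number here means a stronger inhibitor, a higher number a weaker inhibitor), compound 2 gives the lowest of the two numbers, with compound 1 nearest; the step of a 1.4-fold lower number from compound 1 to compound 2 (0.16 log units; within the scatter) lies within the scatter, so the two compounds cannot be ranked against each other. Compound 3, `CN(C)CCn1cnnc1-c1cc(Oc2ccc(NC(=O)N/N=C/c3c[nH]c4ccccc34)cc2F)ccn1`, differs from compound 2 by 1H-indol-3-yl in place of 2,6-dichlorophenyl on a carbon with a double bond to nitrogen. Among the compounds with values here, the only measured step, from compound 1 to compound 2, exchanges one dichlorophenyl for another and stays within the scatter; no measured pair shows what an indol-3-yl in this place does. With so little to lean on, the step of a 1.1-fold higher number from compound 2 to compound 3 (0.02 log units; within the scatter) is expected to remain within the scatter, with a wide range to allow for the unmeasured kind of change. Compound 3 is therefore estimated at 3500 nM, between 1200 nM and 10000 nM.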

Compound 3, half-maximal inhibitory concentration: 3620 nM
Estimate against measurement, compound 3: 1.0-fold (0.01 log units) below; measured number inside the range.
By their numbers in this assay, from the lowest: compounds 2, 3 and 1 (each within the scatter of the next).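

Placing 1H-indol-3-yl on the carbon with a double bond to nitrogen gives a 1.1-fold higher number from compound 2 to compound 3 (0.04 log units; within the scatter) and a 1.3-fold lower number from compound 1 to compound 3 (0.12 log units; within the scatter) in this assay and both steps lie within the scatter. The earlier pair only exchanged one dichlorophenyl for another, whereas this change removes both chlorines and brings in a five-membered aromatic ring with a hydrogen-bond donor, yet compounds 1, 2 and 3 still cannot be told apart in this assay. Nothing available here accounts for this result.

The compounds shown leave open whether any group at this place can produce a step beyond the scatter, for example a carboxylic acid, an amine or a plain alkyl chain in place of the aromatic group. They also leave open whether a smaller aromatic group, such as an unsubstituted phenyl, would fall within the scatter of these three compounds.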